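Bromo for methoxy on the core of compound 2

The source may report more compounds than this note shows. Statements on the series, on what has been measured and on what is new or still open speak of the compounds shown alone.

Measured so far in a functional assay on HepG2 cells (Homo sapiens) for inhibition, read by MTT assay, with a stated time of 24 h; a lower number here means a stronger inhibitor of growth, a higher number a weaker inhibitor of growth:
- compound 1 (`COc1ccc2c(c1)c(-c1nc3ccccc3n1C(=O)c1ccccc1)cn2C`) gives 37900 nM
- compound 2 (`COc1ccc(C(=O)n2c(-c3cn(C)c4ccc(OC)cc34)nc3ccccc32)cc1`) gives 12800 nM
- compound 3 (`COc1ccc2c(c1)c(-c1nc3ccccc3n1C(=O)c1ccc(OC)c(OC)c1)cn2C`) gives 5100 nM

Compound 2 holds the second highest of the three numbers. Compound 4 (`COc1ccc(C(=O)n2c(-c3cn(C)c4ccc(Br)cc34)nc3ccccc32)cc1`) has bromo in place of methoxy on an aromatic carbon of compound 2 (bromo in place of methoxy on an aromatic carbon). For the measured compounds named here, no measured step touches that carbon, and no bromo compound has been measured. The closest evidence is methoxy in place of hydrogen on an aromatic carbon of the other acyl-bearing part, with modest steps: a 3.0-fold lower number from compound 1 to compound 2 (0.47 log units; beyond the scatter) and a 2.5-fold lower number from compound 2 to compound 3 (0.40 log units; beyond the scatter) in this assay. The combined change gives a 7.4-fold lower number from compound 1 to compound 3 (0.87 log units; beyond the scatter) in the same read-out. These steps set the size only, so a step no larger than they are is expected, with its direction open. The estimated change is a 1.3-fold lower number from compound 2 to compound 4 (0.11 log units; within the scatter) in this assay. Compound 4 is estimated at 10000 nM (expected range 3500 nM to 30000 nM).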

Compound 4, concentration for 50% growth inhibition: 18900 nM
The estimate for compound 4 lay 1.9-fold (0.28 log units) below the measured number; measured number inside the range.
By their numbers in this assay, from the lowest: compound 3; then compounds 2, 4 and 1 (each within the scatter of the next, the first and the last beyond it).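

In this assay, for the compounds shown here, bromo in place of methoxy on this aromatic carbon of the shared core gives a 1.5-fold higher number from compound 2 to compound 4 (0.17 log units; within the scatter) and so stays within the scatter, the only reading so far at this position. Against the earlier steps, all on the acyl-bearing part, this exchange on the core leaves the number essentially unmoved, at least with the acyl group of compound 2. Nothing on hand bears on the reason for this result.

Going by these compounds, whether an amine or a carboxylic acid at this carbon would also leave the number unmoved remains open. So does whether bromo behaves the same way with the acyl group of compound 3.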